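The source may hold more compounds than are shown below. What is called first, only, known or untested is meant among the compounds shown, and "the series" means these compounds.

Compound 1 `CCCc1cn(C(c2ccccc2)c2cc3cc(Br)ccc3nc2OC)nn1` gives 11.3% in an ADME assay on PANC-1 cells (Homo sapiens) for cytotoxicity, read by sulforhodamine B assay, with a stated time of 48 h, tested at 10 uM; on this read-out lower numbers stand for less inhibition and higher numbers for more inhibition at the one concentration tested (going by the name of the read-out); compound 2 `COc1nc2ccc(Br)cc2cc1C(c1ccccc1)n1cc(CCO)nn1` gives 19.8%.

Compound 2 is separated from compound 1 only by a number 8.5 percentage points higher from compound 1 to compound 2 (within the scatter), so the two numbers sit within the scatter of each other. Compound 3 `COc1nc2ccc(Br)cc2cc1C(c1ccccc1)n1cc(CO)nn1` differs from compound 2 by hydroxy in place of hydroxymethyl on a saturated chain carbon bound to an aromatic carbon. For the measured compounds named here, the one measured step that bears on this change, a number 8.5 percentage points higher from compound 1 to compound 2 (within the scatter), also reworked the same chain and stayed within the scatter. Compound 3 is therefore expected to move by a number 2.8 percentage points lower from compound 2 to compound 3 (within the scatter), nothing beyond the scatter, and its estimated value in this assay is 17%, with a range from 5% to 30%.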

Compound 3, a percentage reported as inhibition, at one concentration (the size of the read-out at that concentration, not a potency): 15%
Beside the measured number, compound 3's estimate is 2 percentage points above it; measured number inside the range.
By their numbers in this assay, from the lowest: compounds 1, 3 and 2 (each within the scatter of the next).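

In this assay, shortening 2-hydroxyethyl to hydroxymethyl gives a number 4.8 percentage points lower from compound 2 to compound 3 (within the scatter), and hydroxy in place of ethyl on a saturated chain carbon bound to an aromatic carbon gives a number 3.7 percentage points higher from compound 1 to compound 3 (within the scatter). For the compounds shown here, with a second hydroxy-bearing chain now in hand, neither the length of that chain nor the presence of the hydroxy separates these compounds on this read-out, which the single earlier step could not show. Nothing available gives a reason for these small differences. As far as these compounds go, it remains open whether an amine, a carboxylic acid or a longer chain at this position would give a number beyond the scatter of these three.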